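A few compounds are considered here, and "the series" means these few. Any claim that something is new, unique, unknown or untested is made for them only; others in the source may bear on it.

Measured compounds in an assay on membranes from HEK293 cells for displacement of a labelled ligand from Type-2 angiotensin II receptor (Homo sapiens), read by radioligand binding; on this read-out lower numbers stand for stronger inhibition and higher numbers for weaker inhibition:
- compound 1, `CCCCOC(=O)NS(=O)(=O)c1ccc(CCC)cc1-c1ccc(Cn2c(CC(C)C)nc3ccccc32)cc1`: 19 nM
- compound 2, `CCCCOC(=O)NS(=O)(=O)c1ccc(CCC)cc1-c1ccc(Cn2c(CCCC)nc3ccccc32)cc1`: 9.2 nM
- compound 3, `CCCCOC(=O)NS(=O)(=O)c1ccc(CCC)cc1-c1ccc(Cn2c(C(C)(C)C)nc3ccccc32)cc1`: 5.3 nM

All three share one core and differ only in the group carried on the five-membered ring of the fused system. Compound 3 gives the lowest of the three numbers, yet its gap to compound 2, a 1.7-fold lower number from compound 2 to compound 3 (0.24 log units; within the scatter), is within the scatter, so the two cannot be ranked against each other. Only its gap to compound 1, a 3.6-fold lower number from compound 1 to compound 3 (0.55 log units; beyond the scatter), is beyond the scatter, as is a 2.1-fold lower number from compound 1 to compound 2 (0.31 log units; beyond the scatter).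

Compound 4, `CCCCOC(=O)NS(=O)(=O)c1ccc(CCC)cc1-c1ccc(Cn2c(C(F)(F)F)nc3ccccc32)cc1`, is not yet measured. It differs from compound 3 by trifluoromethyl in place of tert-butyl on an aromatic carbon. Among the measured compounds shown here, no measured step exchanges a carbon chain for a fluorine-bearing group, so the three steps say only that changes at this position have moved the number modestly and in no fixed direction. The estimate for compound 4 in this assay is therefore 12 nM, with a range from 3 nM to 50 nM, which means a step of a 2.3-fold higher number from compound 3 to compound 4 (0.35 log units; beyond the scatter) is expected; the range is wide enough to admit a modest change either way.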

Compound 4, inhibition constant: 13 nM
Compound 4: the middle estimate sits 1.1-fold (0.03 log units) below what was measured; measured number inside the range.
By their numbers in this assay, from the lowest: compounds 3, 2, 4 and 1 (each within the scatter of the next, the first and the last beyond it).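

In this assay, among the compounds shown here, trifluoromethyl is the first group at this position that is not built from carbon alone, and it replaces tert-butyl with the same number of heavy atoms and no added ring, hydrogen-bond donor, hydrogen-bond acceptor or charge, yet the exchange gives a 2.5-fold higher number from compound 3 to compound 4 (0.39 log units; beyond the scatter) and so moves the number beyond the scatter. The other two comparisons do not separate trifluoromethyl from the carbon chains, with butyl giving a 1.4-fold higher number from compound 2 to compound 4 (0.15 log units; within the scatter) and isobutyl giving a 1.5-fold lower number from compound 1 to compound 4 (0.16 log units; within the scatter), so this fluorine-bearing group stays inside the span already set by the three carbon groups. Nothing available here accounts for the step from tert-butyl to trifluoromethyl.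

The compounds shown leave open whether a methyl group, a longer fluorine-bearing chain such as pentafluoroethyl, an amine or a carboxylic acid at this position would stay within that span. They also leave open whether the step from tert-butyl to trifluoromethyl would stay the same if a different chain replaced the propyl group on the shared core.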